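The source may report more compounds than this note shows. Statements on the series, on what has been measured and on what is new or still open speak of the compounds shown alone.

Compound 1 `Cc1nc(-c2ccccc2)c(C(=O)N2CCN(c3cccc(C#N)c3)CC2)o1`, compound 2 `Cc1nc(-c2ccccc2)c(C(=O)N2CCN(c3ccccc3Cl)CC2)o1` and compound 3 `Cc1nc(-c2ccccc2)c(C(=O)N2CCN(c3ccccc3F)CC2)o1` share one core and differ only in the aryl group on an amine nitrogen in a ring. In a functional assay on HL-60 cells (Homo sapiens) for inhibition, read by MTT assay, with a stated time of 72 h (a higher number here means a weaker inhibitor, a lower number a stronger inhibitor), compound 1 gives 39.6 nM, compound 2 gives 124 nM and compound 3 gives 147 nM. Compound 3 has the highest number of the three: the steps of a 3.1-fold higher number from compound 1 to compound 2 (0.50 log units; beyond the scatter) and a 3.7-fold higher number from compound 1 to compound 3 (0.57 log units; beyond the scatter) both lie beyond the scatter, whereas the step of a 1.2-fold higher number from compound 2 to compound 3 (0.07 log units; within the scatter) does not, so compound 2 and compound 3 cannot be told apart in this assay.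

Compound 4 `Cc1nc(-c2ccccc2)c(C(=O)N2CCN(c3ccccc3C(F)(F)F)CC2)o1` carries the change (trifluoromethyl in place of fluoro on an aromatic carbon). Going by the values given here, the only measured step at this place, a 1.2-fold higher number from compound 2 to compound 3 (0.07 log units; within the scatter), stayed within the scatter, so the data give no sign that exchanging the group on this aromatic carbon moves the number, and no step beyond the scatter is expected in this assay. Compound 4 is therefore estimated at 150 nM, within a range from 60 nM to 400 nM. The step expected is a 1.0-fold higher number from compound 3 to compound 4 (0.01 log units; within the scatter).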

Compound 4, half-maximal inhibitory concentration: 120 nM
Compound 4: the middle estimate sits 1.3-fold (0.10 log units) above what was measured; measured number inside the range.
By their numbers in this assay, from the lowest: compound 1; then compounds 4, 2 and 3 (each within the scatter of the next).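

In this assay, trifluoromethyl brings four heavy atoms where fluoro has one, yet the number does not move beyond the scatter, with a 1.2-fold lower number from compound 3 to compound 4 (0.09 log units; within the scatter). Exchanging chloro for trifluoromethyl gives the same reading, with a 1.0-fold lower number from compound 2 to compound 4 (0.01 log units; within the scatter), so the 2-fluorophenyl, 2-chlorophenyl and 2-(trifluoromethyl)phenyl compounds cannot be told apart despite the added bulk in atom count, while the 3-cyanophenyl compound remains separate, with a 3.0-fold higher number from compound 1 to compound 4 (0.48 log units; beyond the scatter). Nothing measured here offers an explanation for either finding.

On these data alone, whether an amine or a carboxylic acid on this aromatic carbon would also stay within the scatter remains open. The gap to compound 1 joins a change of group with a change of place on the ring, and the compounds shown cannot separate the two.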